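The source may hold more compounds than are shown below. What is called first, only, known or untested is meant among the compounds shown, and "the series" means these compounds.

Compound 3 `Cc1ccc(C(=O)Nc2cc(-c3ccccc3)nn2-c2ccccc2)cc1C` gives 430 nM in an assay on HEK293 cells for displacement of a labelled ligand from metabotropic glutamate receptor 5 (Rattus norvegicus) (a higher number here means a weaker inhibitor, a lower number a stronger inhibitor), the lowest of the two numbers shown so far. Compound 1 `O=C(Nc1cc(-c2ccccc2)nn1-c1ccccc1)c1cccc([N+](=O)[O-])c1` gives 2220 nM in this assay. For compound 2 `O=C(O)c1ccc(C(=O)Nc2cc(-c3ccccc3)nn2-c2ccccc2)cc1` only a limit is recorded in this assay, > 10000 nM, one of the values that sit at the limit of > 10000 nM in this assay, at which 1 of the 3 values shown sits. The steps of a 5.2-fold lower number from compound 1 to compound 3 (0.71 log units; beyond the scatter) and an at least 23-fold lower number from compound 2 to compound 3 (1.36 log units; beyond the scatter) both change what is attached to the aromatic ring on the carbonyl carbon, and an at least 4.5-fold higher number from compound 1 to compound 2 (0.65 log units; beyond the scatter) shows the same ring with a different substituent. Compound 4 `O=C(Nc1cc(-c2ccccc2)nn1-c1ccccc1)C1CCCCC1` has not yet been measured; it differs from compound 3 by cyclohexyl in place of 3,4-dimethylphenyl on a carbonyl carbon. Among the measured compounds shown here, no measured step exchanges the aromatic ring itself for a non-aromatic one, so the measured steps bear on this change only loosely: they show that the group on the carbonyl carbon shifts the number by a modest to large amount. For compound 4 a modest weakening is expected, a 2.6-fold higher number from compound 3 to compound 4 (0.41 log units; beyond the scatter). The estimate for compound 4 in this assay is 1100 nM, between 300 nM and 4500 nM.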

Compound 4, inhibition constant: 10100 nM
Beside the measured number, compound 4's estimate is 9.2-fold (0.96 log units) below it; measured number outside the range, above it.
By their numbers in this assay, from the lowest: compound 3; then compound 1; then compound 4.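

In this assay, among the compounds shown here, the first exchange of the aromatic ring on the carbonyl carbon for a non-aromatic one, cyclohexyl, costs a large amount: a 23-fold higher number from compound 3 to compound 4 (1.37 log units; beyond the scatter). The same exchange starting from the 3-nitrophenyl group moves the same way but by less, a 4.5-fold higher number from compound 1 to compound 4 (0.66 log units; beyond the scatter), so in both readable cases the aromatic group gives the lower number. The step from compound 2 to compound 4 cannot be read, because compound 2 carries only a limit: the limit of > 10000 nM in this assay, at which 1 of the 4 values shown sits.

The compounds shown do not separate the loss of aromatic character from the loss of the two methyl groups, as a plain phenyl or a 3,4-dimethylcyclohexyl group on the carbonyl carbon would. As far as these compounds go, how an amine or a longer open carbon chain at this position would compare also remains open.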